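The compounds below may be only part of what the source reports. "The series", "measured", "known", "first", "only" and "open" are said of these compounds alone.

In a functional assay on the whole organism with Rattus norvegicus as the target (a lower number here means that less compound is needed, a higher number that more compound is needed for the effect), the measured compounds are
compound 1 `CNc1cc(OC)c(C(=O)NC2CCN(Cc3ccccc3)C2)cc1Cl` with 0.016 mg/kg
compound 2 `COc1cc(N(C)C)c(Cl)cc1C(=O)NC1CCN(Cc2ccccc2)C1` with 0.12 mg/kg

Compound 1 has the lower number of the two. Compound 3 `CCN1CCC(NC(=O)c2cc(Cl)c(NC)cc2OC)C1` keeps the core of compound 1 and differs by methyl in place of phenyl on a saturated chain carbon bound to an amine nitrogen in a ring in the change from benzyl to ethyl. Among the compounds with values here, the only measured step, a 7.5-fold higher number from compound 1 to compound 2 (0.88 log units; beyond the scatter) for methyl in place of hydrogen on a nitrogen on an aromatic ring, lies at another place and gives only a rough scale. Within the data shown here, no measured step covers the new change. A larger move toward a higher number is expected here. The expected change is a 25-fold higher number from compound 1 to compound 3 (1.40 log units; beyond the scatter) with wide uncertainty. For compound 3 the estimate is 0.4 mg/kg with 0.08 mg/kg to 2 mg/kg as its expected range.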

Compound 3, dose for half-maximal effect: 10 mg/kg
The estimate for compound 3 lay 25-fold (1.40 log units) below the measured number; the whole stated range lies below it.
By their numbers in this assay, from the lowest: compound 1; then compound 2; then compound 3.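

In this assay, replacing benzyl with ethyl on the amine nitrogen in the ring gives a 630-fold higher number from compound 1 to compound 3 (2.80 log units; beyond the scatter) at this place. Within the data shown here, that step is much larger than a 7.5-fold higher number from compound 1 to compound 2 (0.88 log units; beyond the scatter) at the nitrogen on the aromatic ring, so the phenyl-to-methyl change is the largest effect seen so far. Nothing available bears on the reason for this loss.

Going by these compounds, it remains open whether the phenyl ring itself or the length of the chain carries the effect. A phenethyl or cyclohexylmethyl group at the same place would help separate these two readings.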